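A Chloro Swap Tested Against a Toxicity Ceiling

This account rests on a few compounds, and the source may have more. Where it says the series, first, only, none or still open, it means among the compounds named here.

Compound 1, `Cc1ccccc1C(=O)Nc1ncc(-c2ccccc2)n1C`: in a toxicity assay on THP-1 cells (Homo sapiens) for inhibition (on this read-out lower numbers stand for higher toxicity in this test and higher numbers for lower toxicity in this test), compound 1 gives > 100000 nM, which is a limit of the assay rather than a number.
Compound 2, `Cc1ccc(C(=O)Nc2ncc(-c3ccccc3)o2)cc1`: compound 2 gives 26000 nM.
Compound 3, `COc1ccc(-c2cnc(NC(=O)c3ccccc3C)n2C)cc1`: compound 3 gives > 100000 nM, again a limit rather than a number.

Compound 1 therefore stands at the limit of > 100000 nM in this assay, at which 2 of the 3 values shown sit, and nothing more precise is known about it. Among the measured compounds shown here, the only measured step that starts from compound 1 is a step that the two limits leave unreadable from compound 1 to compound 3; both ends sit at the limit, so its size cannot be read. For the measured compounds named here, compound 2 carries a number, but it differs from compound 1 in more than one place, so no single step connects them.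

The unmeasured compound 4, `Cn1c(-c2ccccc2)cnc1NC(=O)c1cccc(Cl)c1`, differs from compound 1 by 3-chlorophenyl in place of 2-methylphenyl on a carbonyl carbon. Going by the values given here, no measured step bears on this change with a readable size. With compound 1 and its closest measured neighbour both sitting at the limit, the expectation in this assay is no step beyond the scatter, and most likely another limit. The step expected from compound 1 is a number no higher from compound 1 to compound 4 (the limit leaves the size open). Compound 4 is thus estimated at 100000 nM, with a range from 30000 nM to 300000 nM.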

Compound 4, half-maximal cytotoxic concentration: > 50000 nM
Compound 4 gave a limit, no number; the forecaster's own chance of this, stated with the estimate: 60%; the middle value is on the limit's open side.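

In this assay compound 4 gives > 50000 nM, which is a limit and not a number. Among the compounds shown here, compound 1 also stands at a limit, so no step from compound 1 to compound 4 can be read. The compounds shown leave open whether 3-chlorophenyl in place of 2-methylphenyl changes the result in this assay at all, and in which direction.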